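Swapping a chlorobenzyl for a fluorobenzyl ether

The source may hold more compounds than are shown below. What is called first, only, known or untested is meant among the compounds shown, and "the series" means these compounds.

Measured compounds:
Compound 1 `Cc1ccc(NC(=S)NC(=O)c2ccc(OCc3ccccc3F)cc2)cc1-c1nc2ccccc2[nH]1`: 2420 nM
Compound 2 `Cc1ccc(NC(=S)NC(=O)c2ccc(OCc3ccccc3Cl)cc2)cc1-c1nc2ccccc2[nH]1`: 51400 nM
Compound 3 `Cc1ccc(NC(=O)NC(=O)c2ccc(OCc3cccc(Cl)c3)cc2)cc1-c1nc2ccccc2[nH]1`: 28000 nM

All three compounds share the same core and were tested in a functional assay on MNK45 cells (Homo sapiens) for inhibition, read by MTT assay, with a stated time of 48 h; a lower number here means a stronger inhibitor, a higher number a weaker inhibitor. Compound 3 stands second highest of the three numbers: its nearest neighbour is compound 2, which gives 51400 nM, a value within the scatter of compound 3, so no order between the two can be claimed. Its furthest neighbour is compound 1, which gives 2420 nM, a clearly lower number.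

Compound 4 `Cc1ccc(NC(=O)NC(=O)c2ccc(OCc3ccccc3F)cc2)cc1-c1nc2ccccc2[nH]1` has not yet been measured. Its difference from compound 3 is 2-fluorophenyl in place of 3-chlorophenyl on a saturated chain carbon bound to an oxygen on an aromatic ring. Among the measured compounds shown here, the one measured step that bears on this is a 21-fold higher number from compound 1 to compound 2 (1.33 log units; beyond the scatter), where the halogen on the benzyl ring was changed while everything else stayed fixed. The step from compound 3 to compound 4 runs the other way, towards fluorine, but it also moves the halogen on the ring and sits on a urea rather than a thiourea linker, so the comparison is only partial.

A lower number is therefore expected for compound 4, with a step of about a 4.7-fold lower number from compound 3 to compound 4 (0.67 log units; beyond the scatter) in this assay. The estimate for compound 4 is 6000 nM, in the range 1500 nM to 25000 nM.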

Compound 4, half-maximal inhibitory concentration: 1830 nM
The estimate for compound 4 lay 3.3-fold (0.52 log units) above the measured number; measured number inside the range.
By their numbers in this assay, from the lowest: compounds 4 and 1 (each within the scatter of the next); then compounds 3 and 2 (each within the scatter of the next).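

In this assay the change from (3-chlorobenzyl)oxy to (2-fluorobenzyl)oxy gives a 15-fold lower number from compound 3 to compound 4 (1.18 log units; beyond the scatter). The large gap seen between the fluoro and chloro compounds on the thiourea linker therefore has a counterpart on the urea linker, although here the place of the halogen on the ring changes as well. Compound 4 (1830 nM) and compound 1 (2420 nM) lie within the scatter of each other, so with the 2-fluorobenzyl ether in place, this pair gives no reading of any difference between urea and thiourea. No measurement at hand explains why the change on the benzyl ring has so large an effect.

This single move replaces chlorine with fluorine and also shifts the halogen on the ring, so the compounds shown leave open which of the two changes accounts for the step. Also open is how a benzyl ring with no halogen at all, or one carrying a methoxy group or a nitrile, would read here, since every benzyl ring shown bears fluorine or chlorine.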